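A few compounds are considered here, and "the series" means these few. Any claim that something is new, unique, unknown or untested is made for them only; others in the source may bear on it.

The measured compounds and their numbers:

Compound 1 `COc1ccc(S(=O)(=O)N2CCN(c3nc(N)c4cc(OC)c(OC)cc4n3)CC2)cc1` gives 39000 nM.
Compound 2 `COc1cc2nc(N3CCN(S(=O)(=O)c4cccc(C(=O)O)c4)CC3)nc(N)c2cc1OC` gives 53000 nM.
Compound 3 `COc1cc2nc(N3CCN(S(=O)(=O)c4cc(F)c(Cl)c(C(=O)O)c4)CC3)nc(N)c2cc1OC` gives 56000 nM.

All three were tested in a functional assay on PC-3 cells (Homo sapiens) for inhibition; on this read-out lower numbers stand for stronger inhibition and higher numbers for weaker inhibition. Compound 1 stands at the lowest of the three numbers, but its separation from the other two is small: the step of a 1.4-fold higher number from compound 1 to compound 2 (0.13 log units; within the scatter) and the step of a 1.4-fold higher number from compound 1 to compound 3 (0.16 log units; within the scatter) both lie within the scatter, as does the step of a 1.1-fold higher number from compound 2 to compound 3 (0.02 log units; within the scatter), so the three compounds cannot be told apart on this read-out.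

Compound 4 `CCCCc1ccc(-c2ccc(S(=O)(=O)N3CCN(c4nc(N)c5cc(OC)c(OC)cc5n4)CC3)cc2)cc1` is the unmeasured compound. It differs from compound 1 in one place: 4-butylphenyl in place of methoxy on an aromatic carbon.

Within the data shown here, none of the measured steps covers this kind of change. Each of them swaps the whole 4-methoxyphenyl group for a carboxyphenyl group, and each stays within the scatter, so they offer no direction to lean on. Among the measured compounds shown here, with no step bearing on a 4-butylphenyl group entering where methoxy leaves, the expected step of a 1.3-fold lower number from compound 1 to compound 4 (0.11 log units; within the scatter) is of no clear direction, and the range around it must be wide. Compound 4 is therefore estimated at 30000 nM in this assay, with a range from 7000 nM to 120000 nM.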

Compound 4, half-maximal inhibitory concentration: 3400 nM
Compound 4: middle estimate off by 8.8-fold (0.95 log units), on the high side; the whole stated range lies above it.
By their numbers in this assay, from the lowest: compound 4; then compounds 1, 2 and 3 (each within the scatter of the next).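

Putting 4-butylphenyl in place of methoxy, on an aromatic carbon para to a large group, gives an 11-fold lower number from compound 1 to compound 4 (1.06 log units; beyond the scatter) in this assay. This is the first step among these compounds that lies beyond the scatter, so the read-out can move clearly with a change at this one position, whereas the swaps of the whole 4-methoxyphenyl group for a carboxyphenyl group left the numbers indistinguishable. Nothing available here accounts for the stronger inhibition seen with the larger group, which adds a six-membered aromatic ring and a butyl chain in a single change.

The compounds shown leave open which part of 4-butylphenyl goes with the lower number, since the added ring and the chain always appear together; a plain phenyl group, or a phenyl group carrying a methyl group or a longer chain, would separate the two. They also leave open whether the chain must be made of carbon only, as a phenyl group carrying an amine or a carboxylic acid at the end of the chain would be a different case.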